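Moving one methoxy group: from compound 3 to compound 4

The source may report more compounds than this note shows. Statements on the series, on what has been measured and on what is new or still open speak of the compounds shown alone.

Compound 1 `COc1ccc(Nc2nc(N)c(C(=O)c3ccccc3)s2)cc1`: 300 nM
Compound 2 `COc1cccc(C(=O)c2sc(Nc3ccccc3)nc2N)c1`: 2300 nM
Compound 3 `COc1ccc(Nc2nc(N)c(C(=O)c3ccccc3OC)s2)cc1`: 17 nM

In a functional assay on CCRF-CEM cells (Homo sapiens) for antiproliferative activity, read by cell counting, with a stated time of 2 days (on this read-out lower numbers stand for stronger inhibition and higher numbers for weaker inhibition), compound 3 gives 17 nM, the lowest of the three numbers and so the strongest inhibition measured so far. The next compound to be tested is compound 4 `COc1ccc(Nc2nc(N)c(C(=O)c3cccc(OC)c3)s2)cc1`, which has the same atoms as compound 3, joined differently: 3-methoxyphenyl in place of 2-methoxyphenyl on a carbonyl carbon.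

Among the compounds with values here, no measured step shows this exact swap, so the evidence is indirect. The closest is an 18-fold lower number from compound 1 to compound 3 (1.25 log units; beyond the scatter), a large step made by putting methoxy in place of hydrogen on an aromatic carbon. It shows that this part of the molecule can matter greatly, but not whether 3-methoxyphenyl would keep the gain. Within the data shown here, compound 2, the only measured compound carrying 3-methoxyphenyl on a carbonyl carbon, gives 2300 nM, a weak result that hints it may not.

The expectation is that most of the gain is lost, a large move toward weaker inhibition, estimated as a 12-fold higher number from compound 3 to compound 4 (1.07 log units; beyond the scatter). For compound 4 the estimated value in this assay is 200 nM, with an expected range from 40 nM to 1000 nM.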

Compound 4, half-maximal inhibitory concentration: 9.9 nM
The estimate for compound 4 lay 20-fold (1.31 log units) above the measured number; the whole stated range lies above it.
By their numbers in this assay, from the lowest: compounds 4 and 3 (each within the scatter of the next); then compound 1; then compound 2.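

In this assay, moving the methoxy group gives a 1.7-fold lower number from compound 3 to compound 4 (0.23 log units; within the scatter), so on this core 2-methoxyphenyl and 3-methoxyphenyl on a carbonyl carbon cannot be told apart, and the gain over the plain phenyl of compound 1 survives the move, with a 30-fold lower number from compound 1 to compound 4 (1.48 log units; beyond the scatter). The weak result of compound 2 therefore cannot be pinned on 3-methoxyphenyl alone, since compound 4 carries the same group and adding a methoxy group elsewhere on the molecule gives a 230-fold lower number from compound 2 to compound 4 (2.37 log units; beyond the scatter). The new pair also shows that putting methoxy in place of hydrogen has no single fixed size of effect in this series, and that its size depends on the compound it is made on: the same change on two cores in this assay, an 18-fold lower number (1.25 log units; beyond the scatter) from compound 1 to compound 3 and a 230-fold lower number (2.37 log units; beyond the scatter) from compound 2 to compound 4, 13-fold (1.12 log units) apart, beyond the scatter of two such steps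

The compounds shown leave open whether a different group, such as ethoxy or an amine, in place of the methoxy of 3-methoxyphenyl would hold this level of inhibition. They also leave open whether 2-methoxyphenyl on a carbonyl carbon would stay level with 3-methoxyphenyl on the core of compound 2, where the second methoxy group is missing.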